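One Extra Carbon on the Acyl Group of Compound 3

This account rests on a few compounds, and the source may have more. Where it says the series, first, only, none or still open, it means among the compounds named here.

Compound 3 `CC(=O)n1c(=S)[nH]c2ccccc21` stands highest of the three compounds measured in a physicochemical assay for solubility (on this read-out lower numbers stand for lower solubility and higher numbers for higher solubility), giving 460000 nM. The nearest value belongs to compound 2 `O=C(CCc1ccccc1)n1c(=S)[nH]c2ccccc21`, which in this assay gives 100000 nM, a gap beyond the usual scatter. Compound 1 `CCCCCCCCCCCCCCCC(=O)n1c(=S)oc2ccccc21` lies furthest away, giving 63000 nM in this assay, again beyond the scatter. No pair among these three differs in just one place, so their values can only be read as they are, without a single step to point at.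

Among the compounds with values here, compound 4 `CCC(=O)n1c(=S)[nH]c2ccccc21` is the one compound not yet measured. It differs from compound 3 in one place: methyl in place of hydrogen on a saturated chain carbon bound to a carbonyl carbon. Seen one bond further out, acetyl becomes propanoyl.

Without any measured one-place step in this set, the expectation rests on compound 3 alone and on the small size of the change. Since compound 3 holds 460000 nM, compound 4 is expected to come out slightly lower, with the step of a 1.5-fold lower number from compound 3 to compound 4 (0.19 log units; within the scatter) expected to stay within the usual scatter. The value for compound 4 is estimated at 300000 nM, within a range from 150000 nM to 550000 nM.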

Compound 4, solubility: 180000 nM
Compound 4: middle estimate off by 1.7-fold (0.22 log units), on the high side, and the stated range covers the measured number.
By their numbers in this assay, from the lowest: compounds 1, 2 and 4 (each within the scatter of the next, the first and the last beyond it); then compound 3.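

In this assay, within the data shown here, the first one-place step in this set shows that a small change at this position can count: methyl in place of hydrogen on a saturated chain carbon bound to a carbonyl carbon, which turns acetyl into propanoyl, gives a drop beyond the usual scatter (a 2.6-fold lower number from compound 3 to compound 4 (0.41 log units; beyond the scatter)), though a modest one. The second step changes a different place, with hydrogen in place of phenyl on a saturated chain carbon, two bonds along the chain from a carbonyl carbon (a 1.8-fold higher number from compound 2 to compound 4 (0.26 log units; within the scatter)), and it stays within the scatter, so compound 2 and compound 4 cannot be told apart on this read-out. Nothing in the data explains why either step has the size it has.

A single step also cannot show whether a longer chain in place of the methyl would continue the drop seen with compound 4 or leave the number where it is. Nor do these compounds show what an amine or a carboxylic acid on that same saturated chain carbon would do.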